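The source may report more compounds than this note shows. Statements on the series, on what has been measured and on what is new or still open speak of the compounds shown alone.

In a physicochemical assay for solubility, at pH 7.4 (on this read-out lower numbers stand for lower solubility and higher numbers for higher solubility), compound 1 `COC(=O)c1cccc(NC(=O)Nc2cc(C)nc3ccccc23)c1` gives 600 nM and compound 2 `COc1cccc(NC(=O)Nc2cc(C)nc3ccccc23)c1` gives 1200 nM. These two numbers lie within the usual scatter of repeated measurements, and the two compounds cannot be ranked. The next structure is compound 3 `Cc1cc(NC(=O)Nc2cccc(OC(F)(F)F)c2)c2ccccc2n1` and it differs from compound 2 as follows: trifluoromethyl in place of methyl on an oxygen on an aromatic ring. In words, trifluoromethyl takes the place of methyl on an oxygen on an aromatic ring, which turns methoxy into trifluoromethoxy. Within the data shown here, no measured pair makes this exact change. Among the measured compounds shown here, the only evidence is a 2.0-fold higher number from compound 1 to compound 2 (0.30 log units; within the scatter) where methoxy replaces methoxycarbonyl on an aromatic carbon. That single step is thin support, and no step beyond the scatter is expected in this assay here. The estimated change is a 1.5-fold lower number from compound 2 to compound 3 (0.18 log units; within the scatter) and it stays within the scatter. For compound 3 the expected value is 800 nM with an estimated range from 300 nM at the low end to 2000 nM at the high end.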

Compound 3, solubility: 600 nM
Compound 3: the middle estimate sits 1.3-fold (0.12 log units) above what was measured, within the range that was stated.
By their numbers in this assay, from the lowest: compounds 1, 3 and 2 (each within the scatter of the next).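

In this assay, the swap of methyl for trifluoromethyl on an oxygen on an aromatic ring gives a 2.0-fold lower number from compound 2 to compound 3 (0.30 log units; within the scatter), so this first direct test of a change on that oxygen stays within the scatter. Trifluoromethoxy in place of methoxycarbonyl gives no change at the digits printed from compound 1 to compound 3 (within the scatter), which also stays within the scatter, so methoxycarbonyl, methoxy and trifluoromethoxy now form a set of three groups that this read-out cannot rank. No other measurement shown here helps to interpret these steps.

The compounds shown all carry an uncharged group at this place, and none of their steps goes beyond the scatter. From the compounds shown here alone, whether an amine or a carboxylic acid there would give a step beyond the scatter remains open, as does the effect of a longer chain on the oxygen.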